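The source may report more compounds than this note shows. Statements on the series, on what has been measured and on what is new or still open speak of the compounds shown alone.

Values measured in a toxicity assay on MT4 cells (Homo sapiens) for cytotoxicity, read by MTT assay; on this read-out lower numbers stand for higher toxicity in this test and higher numbers for lower toxicity in this test:

- compound 1 `Cc1cc(-c2ccc(Cl)cc2)cc(C)c1Oc1cc(N)nc(Nc2ccc(C#N)cc2)n1` gives 21500 nM
- compound 2 `Cc1ccccc1-c1cc(C)c(Oc2cc(N)nc(Nc3ccc(C#N)cc3)n2)c(C)c1` gives 25600 nM
- compound 3 `COc1ccccc1-c1cc(C)c(Oc2cc(N)nc(Nc3ccc(C#N)cc3)n2)c(C)c1` gives 21800 nM

Within the data shown here, on these numbers compound 3 stands level with the other two, and no pair of the three separates beyond the scatter. Compound 4 `COc1ccc(-c2cc(C)c(Oc3cc(N)nc(Nc4ccc(C#N)cc4)n3)c(C)c2)cc1` has the same atoms as compound 3, joined differently, with 4-methoxyphenyl in place of 2-methoxyphenyl on an aromatic carbon. Among the measured compounds shown here, no measured step makes this exact move, so the evidence is indirect. Exchanging 4-chlorophenyl for 2-methylphenyl gave a 1.2-fold higher number from compound 1 to compound 2 (0.08 log units; within the scatter) and exchanging it for 2-methoxyphenyl gave a 1.0-fold higher number from compound 1 to compound 3 (0.01 log units; within the scatter) while methoxy in place of methyl gave a 1.2-fold lower number from compound 2 to compound 3 (0.07 log units; within the scatter) in the same test. All three steps are small, and none of them reaches beyond the scatter. Changes to this group have therefore not yet moved the number in this assay among these few compounds, although three compounds are a thin basis. No direction can be argued from them. The expected outcome is a 1.0-fold higher number from compound 3 to compound 4 (0.00 log units; within the scatter) and no step beyond the scatter is anticipated. For compound 4 the estimated value is 22000 nM with an expected range from 11000 nM to 45000 nM in this test.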

Compound 4, half-maximal cytotoxic concentration: 10700 nM
For compound 4 the middle estimate is 2.1-fold (0.31 log units) above the measured one; the measured number lies below the stated range.
By their numbers in this assay, from the lowest: compounds 4, 1, 3 and 2 (each within the scatter of the next, the first and the last beyond it).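

In this assay, among these compounds, moving the methoxy group within the same aromatic substituent gives a 2.0-fold lower number from compound 3 to compound 4 (0.31 log units; beyond the scatter) and 4-methoxyphenyl in place of 2-methylphenyl gives a 2.4-fold lower number from compound 2 to compound 4 (0.38 log units; beyond the scatter) in this test, so this position, para to a large group and meta to two methyl groups, is no longer as flat as the earlier steps suggested: the arrangement of the substituent on the ring can move the number beyond the scatter, even with no change in atoms between compound 3 and compound 4. The arrangement does not settle the matter alone, since methoxy in place of chloro gives a 2.0-fold lower number from compound 1 to compound 4 (0.30 log units; within the scatter) and stays within the scatter, so compound 1, which also carries its substituent in the 4-position of the name, goes against any simple split between the 4-substituted and 2-substituted compounds. Nothing available accounts for the shift.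

The compounds shown leave open whether the lower number belongs to the methoxy group in particular or would persist with another group in its place, such as an amine or a carboxylic acid. They also leave open what a 3-methoxyphenyl or an unsubstituted phenyl would give in this test.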